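Swapping Chloro for Methoxy on the Chlorobenzyl Ring

The source may report more compounds than this note shows. Statements on the series, on what has been measured and on what is new or still open speak of the compounds shown alone.

Compound 1 `COc1cccc(OC)c1OCCNCCOc1ccccc1OCc1cccc(Cl)c1` is one of two measured compounds. In an assay on CHO cells for displacement of a labelled ligand from Alpha-1D adrenergic receptor (Homo sapiens) (on this read-out higher numbers stand for weaker inhibition and lower numbers for stronger inhibition), compound 1 gives 0.0501 nM. Compound 2 `COc1cccc(OC)c1OCCNCCOc1ccccc1OCc1ccc([N+](=O)[O-])cc1` carries a 4-nitrophenyl in place of the 3-chlorophenyl on a saturated chain carbon bound to an oxygen on an aromatic ring, and in this assay compound 2 gives 0.0501 nM. The step of no change at the digits printed from compound 1 to compound 2 (within the scatter) shows that exchanging the substituent on this outer ring left the read-out where it was, so compound 1 stands level with compound 2 on the numbers shown.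

Compound 3 `COc1cccc(COc2ccccc2OCCNCCOc2c(OC)cccc2OC)c1` differs from compound 1 in one place: methoxy in place of chloro on an aromatic carbon. For the measured compounds named here, the only measured step that bears on this is no change at the digits printed from compound 1 to compound 2 (within the scatter), in which a different substituent on the same ring brought no change beyond the scatter. That single step gives no sign that the substituent on this ring sets the read-out, so the expectation is a step of about a 1.0-fold lower number from compound 1 to compound 3 (0.00 log units; within the scatter), nothing beyond the scatter. The estimate for compound 3 in this assay is therefore 0.05 nM, with a range from 0.02 nM to 0.13 nM.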

Compound 3, inhibition constant: 0.316 nM
For compound 3 the middle estimate is 6.3-fold (0.80 log units) below the measured one; measured number above the stated range.
By their numbers in this assay, from the lowest: compounds 1 and 2 (each within the scatter of the next); then compound 3.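

In this assay, this position on the outer ring does respond to what is placed on it: methoxy in place of chloro gives a 6.3-fold higher number from compound 1 to compound 3 (0.80 log units; beyond the scatter) and so moves the read-out towards weaker inhibition, something the earlier pair, level with each other, gave no hint of. The other listed step points the same way, as 3-methoxyphenyl in place of 4-nitrophenyl gives a 6.3-fold higher number from compound 2 to compound 3 (0.80 log units; beyond the scatter), so the level result of the earlier pair cannot be read as this ring accepting any substituent. The data shown offer no measured explanation for why methoxy differs from chloro and nitro here.

For the compounds shown here, with only three substituents on this ring, it stays open whether the shift belongs to methoxy alone or would also appear with other groups on the same carbon, such as a hydroxyl, an amine or an ethoxy. On these data alone, it also stays open whether methoxy would give the same result at another place on the ring, or whether the shift would hold on a different core.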